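A few compounds are considered here, and "the series" means these few. Any claim that something is new, unique, unknown or untested is made for them only; others in the source may bear on it.

Compounds measured so far:
- compound 1, `COc1cc(-c2nnc3n2NC(c2ccco2)C(C(=O)c2cccc(Br)c2)S3)cc(OC)c1OC`: 36900 nM
- compound 2, `COc1cc(-c2nnc3n2NC(c2ccco2)C(C(=O)c2ccc(C(F)(F)F)cc2)S3)cc(OC)c1OC`: 37200 nM

In a functional assay on A549 cells (Homo sapiens) for cytotoxicity, read by MTT assay, with a stated time of 48 h (on this read-out lower numbers stand for stronger inhibition and higher numbers for weaker inhibition), compound 1 gives 36900 nM, and compound 2 gives 37200 nM. Compound 2 stands with the higher of these two numbers, but the step of a 1.0-fold higher number from compound 1 to compound 2 (0.00 log units; within the scatter) lies within the scatter, so the two compounds cannot be told apart. Compound 3 is `COc1cc(-c2nnc3n2NC(c2ccco2)C(C(=O)c2ccccc2C)S3)cc(OC)c1OC`; it differs from compound 2 in one place: 2-methylphenyl in place of 4-(trifluoromethyl)phenyl on a carbonyl carbon. For the measured compounds named here, only the step from compound 1 to compound 2 bears on this change, and it was flat. Compound 3 is therefore expected to give a number close to compound 2, with the step of a 1.0-fold lower number from compound 2 to compound 3 (0.00 log units; within the scatter), an estimate of 37000 nM, expected between 15000 nM and 90000 nM.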

Compound 3, half-maximal inhibitory concentration: 80000 nM
For compound 3 the middle estimate is 2.2-fold (0.33 log units) below the measured one; the measured number falls inside the stated range.
By their numbers in this assay, from the lowest: compounds 1 and 2 (each within the scatter of the next); then compound 3.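

Where compounds 1 and 2 showed no response to the aryl group on this carbonyl, 2-methylphenyl does shift the number, giving a 2.2-fold higher number from compound 2 to compound 3 (0.33 log units; beyond the scatter) and a 2.2-fold higher number from compound 1 to compound 3 (0.34 log units; beyond the scatter). Both steps are modest, but they show that this position is not indifferent to the group it carries, and the change here goes towards weaker inhibition. Nothing available explains this shift.

Open, from the compounds shown here alone, is whether the methyl itself or its place on the ring matters, which 4-methylphenyl or plain phenyl could help settle. Also open, going by these compounds, is whether a group such as an amine or a carboxylic acid on this ring would lower the number.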